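Replacing a Benzyl Group with 3-Aminophenyl on a Shared Core

The source may report more compounds than this note shows. Statements on the series, on what has been measured and on what is new or still open speak of the compounds shown alone.

The study centres on a set of bromine-bearing bicyclic amides. Compound 1 `O=C(NCc1ccc(F)cc1)c1nc(Br)c2cccnc2c1NCc1ccccc1` carries a benzylamino group on the core and a fluorobenzyl amide; in a functional assay on MCF7 cells (Homo sapiens) for cytotoxicity, read by MTT assay, with a stated time of 72 h (on this read-out higher numbers stand for weaker inhibition and lower numbers for stronger inhibition), compound 1 is recorded as "not determined" (no result reported), so its standing cannot be given. Among the compounds with values here, the only measured member is compound 2 `N[C@H]1CC[C@H](Nc2c(C(=O)NCc3ccccn3)nc(Br)c3cccnc23)CC1`, which bears a diaminocyclohexyl group and a pyridylmethyl amide; in this assay compound 2 gives 15000 nM, a weak result.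

Compound 3 `Nc1cccc(Nc2c(C(=O)NCc3ccc(F)cc3)nc(Br)c3cccnc23)c1` is the compound still to be tested. The change from compound 1 to compound 3 is 3-aminophenyl in place of benzyl on a nitrogen on an aromatic ring. Compound 1 has no number in this assay. The size of this step in this assay cannot be anchored, and no direction can be claimed; the expectation rests on compound 2 alone.

Compound 3 is therefore expected to sit in the same weak region in this assay, estimated at 12000 nM with a range from 3000 nM to 50000 nM, because compound 2 gives 15000 nM on this closely related core. The measured result will settle the matter.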

Compound 3, half-maximal inhibitory concentration: 8000 nM
For compound 3 the middle estimate is 1.5-fold (0.18 log units) above the measured one; measured number inside the range.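

In this assay, within the data shown here, compound 1 stands as "not determined" (no result reported), so no step from it to compound 3 can be read. The compounds shown leave open how exchanging benzyl for 3-aminophenyl on the shared core alters cytotoxicity, in size or in direction. No other data shown here bear on the result of compound 3.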